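A few compounds are considered here, and "the series" means these few. Any claim that something is new, unique, unknown or untested is made for them only; others in the source may bear on it.

Compound 1 `CNC(=O)c1cccc(Cn2nc(C)c(NC(=O)c3ccc(COC4CCCCC4)cc3)c2C)c1` and compound 2 `CNC(=O)c1cccc(Cn2nc(C)c(NC(=O)c3ccc(COc4ccc(OC)cc4)cc3)c2C)c1` share one core and differ only in the group attached to an oxygen on a saturated carbon. In a functional assay on MIA PaCa-2 cells (Homo sapiens) for antiproliferative activity, read by MTT assay, with a stated time of 72 h (on this read-out lower numbers stand for an effect already at smaller amounts and higher numbers for an effect only at larger amounts of compound), compound 1 gives 14000 nM, the highest of the two numbers recorded, and its nearest neighbour compound 2 gives 8000 nM. Going by the values given here, the single measured step, a 1.8-fold lower number from compound 1 to compound 2 (0.24 log units; within the scatter), is the only one that bears on the unmeasured compound 3 `CNC(=O)c1cccc(Cn2nc(C)c(NC(=O)c3ccc(COc4cccc(C(F)(F)F)c4)cc3)c2C)c1`, in which (3-(trifluoromethyl)phenyl in place of cyclohexyl on an oxygen on a saturated carbon). That one step exchanged the same saturated ring for an aromatic ring and did not leave the scatter, and nothing else in the data points to a larger shift for a differently substituted aromatic ring. The expected step in this assay is therefore a 1.4-fold lower number from compound 1 to compound 3 (0.15 log units; within the scatter), not beyond the scatter in either direction. Compound 3 is estimated at 10000 nM, with a range from 4000 nM to 25000 nM.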

Compound 3, half-maximal effective concentration: 2300 nM
Compound 3: the middle estimate sits 4.3-fold (0.64 log units) above what was measured; the measured number lies below the stated range.
By their numbers in this assay, from the lowest: compound 3; then compounds 2 and 1 (each within the scatter of the next).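

At the group on the oxygen, the change to 3-(trifluoromethyl)phenyl moves the read-out in this assay beyond the scatter, with a 6.1-fold lower number from compound 1 to compound 3 (0.78 log units; beyond the scatter) on this exchange, whereas replacing cyclohexyl with 4-methoxyphenyl had stayed within it. The two aromatic groups are not interchangeable here, as a 3.5-fold lower number from compound 2 to compound 3 (0.54 log units; beyond the scatter) shows, so having an aromatic ring on this oxygen does not by itself set the number; what that ring carries matters as well. Nothing among the available measurements accounts for this difference.

Going by these compounds, it remains open whether the lower number depends on the trifluoromethyl group itself or would also appear with a chlorine or a nitrile in its place on the phenyl ring. Also open, on these data alone, is how an amine or a carboxylic acid on that ring would fare.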